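A 4-nitrophenyl swap with little precedent

The source may report more compounds than this note shows. Statements on the series, on what has been measured and on what is new or still open speak of the compounds shown alone.

Of the compounds shown here, two sharing one core have been measured in a functional assay on K562 cells (Homo sapiens) for antiproliferative activity, read by MTT assay; a lower number here means a stronger inhibitor, a higher number a weaker inhibitor. Compound 1 `Cc1ccc(/C(=N/NC(=S)NCCCCCC(=O)NO)c2ccccc2)cc1`, which carries a 4-methylphenyl group, gives 4340 nM. Compound 2 `O=C(CCCCCNC(=S)N/N=C(\c1ccccc1)c1ccccc1F)NO`, which carries a 2-fluorophenyl group, gives 4630 nM. Within the data shown here, compound 2 therefore stands level with compound 1, the only other compound measured so far.

Compound 3 `O=C(CCCCCNC(=S)N/N=C(\c1ccccc1)c1ccc([N+](=O)[O-])cc1)NO` has not yet been measured. It keeps the core of compound 2 but has 4-nitrophenyl in place of 2-fluorophenyl on a carbon with a double bond to nitrogen.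

Among the measured compounds shown here, only one measured step bears on this change, since compound 1 and compound 2 differ at this same place. That step is a 1.1-fold higher number from compound 1 to compound 2 (0.03 log units; within the scatter). On this single step, no change beyond the scatter is expected in this assay. The evidence is thin, however, as neither measured compound carries a nitro group, and the range must stay wide. The expected step is a 1.0-fold lower number from compound 2 to compound 3 (0.01 log units; within the scatter). For compound 3 the estimated value is 4500 nM, with a range from 1700 nM to 11000 nM.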

Compound 3, half-maximal inhibitory concentration: 2890 nM
Compound 3: middle estimate off by 1.6-fold (0.19 log units), on the high side, and the stated range covers the measured number.
By their numbers in this assay, from the lowest: compounds 3, 1 and 2 (each within the scatter of the next).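

In this assay, the nitro group widens the picture without moving the result beyond the scatter: a 1.6-fold lower number from compound 2 to compound 3 (0.20 log units; within the scatter), and a 1.5-fold lower number from compound 1 to compound 3 (0.18 log units; within the scatter). The earlier pair had shown only that 4-methylphenyl and 2-fluorophenyl cannot be told apart at this position, whereas 4-nitrophenyl differs from both by bringing in a double bond outside aromatic rings and two hydrogen-bond acceptors, and even so, the three compounds remain level within the scatter. There is no measurement here that could explain why these numbers sit so close together.

As far as these compounds go, all three compounds keep a six-membered aromatic ring of carbon only at this place, so it remains open whether a non-aromatic group such as cyclohexyl would give a step beyond the scatter, or whether an amine or a carboxylic acid on the aromatic ring would do so. The chain of the shared core is also the same throughout, which leaves the effect of a longer chain unknown.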